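Aryl Swap on a Dialkylamino Pyrazolopyridine Series

A few compounds are considered here, and "the series" means these few. Any claim that something is new, unique, unknown or untested is made for them only; others in the source may bear on it.

Measured compounds:
compound 1, `CCCN(CC)c1cc(C)nc2c(-c3ccc(Cl)cc3Cl)nn(C)c12`, 4.1 nM;
compound 2, `CCCN(CC1CC1)c1cc(C)nc2c(-c3ccc(Cl)cc3Cl)nn(C)c12`, 1.7 nM;
compound 3, `CCCCN(CCCC)c1cc(C)nc2c(-c3ccc(Cl)cc3Cl)nn(C)c12`, 0.62 nM.

In an assay on HEK293 cells for displacement of a labelled ligand from corticotropin-releasing factor receptor 1 (Homo sapiens) (a lower number here means a stronger inhibitor, a higher number a weaker inhibitor), compound 3 holds the lowest number of the three. Compound 2 sits nearest to it, and the gap is a 2.7-fold lower number from compound 2 to compound 3 (0.44 log units; beyond the scatter); compound 1 lies furthest, with a 6.6-fold lower number from compound 1 to compound 3 (0.82 log units; beyond the scatter). The remaining step, a 2.4-fold lower number from compound 1 to compound 2 (0.38 log units; beyond the scatter), is of similar modest size. All three measured steps alter only the dialkylamino group on the six-membered ring of the shared core; the aryl group on the five-membered ring is the same in every one.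

Compound 4, `CCCCN(CCCC)c1cc(C)nc2c(-c3c(C)cc(C)cc3Cl)nn(C)c12`, differs from compound 3 by 2-chloro-4,6-dimethylphenyl in place of 2,4-dichlorophenyl on an aromatic carbon. Within the data shown here, no measured step touches this part of the structure, so none of the steps bears directly on the change. The amino-group steps show the series tolerates modest variation without a large swing in this assay, but they give no guide to direction here. A step of a 1.9-fold higher number from compound 3 to compound 4 (0.29 log units; within the scatter) is therefore expected, treated as uncertain in sign. Compound 4 is estimated at 1.2 nM, within a range of 0.3 nM to 5 nM.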

Compound 4, inhibition constant: 2.1 nM
Beside the measured number, compound 4's estimate is 1.8-fold (0.24 log units) below it, within the range that was stated.
By their numbers in this assay, from the lowest: compound 3; then compounds 2, 4 and 1 (each within the scatter of the next, the first and the last beyond it).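

Among these compounds, the step of a 3.4-fold higher number from compound 3 to compound 4 (0.53 log units; beyond the scatter) in this assay is the first reading at this aromatic carbon of the five-membered ring, where every earlier compound carried 2,4-dichlorophenyl. It shows that, on the dibutylamino compounds, 2-chloro-4,6-dimethylphenyl gives a weaker inhibitor than 2,4-dichlorophenyl, by a modest step that lies beyond the scatter, so the aryl group also moves the number and the amino group is not the only place that does. Nothing available explains why the number rises with this change.

The swap changes the aryl group in more than one place at once, so the shown compounds cannot say how much of the step belongs to the loss of one chlorine and how much to the two methyl groups; aryl groups such as 2,4-dimethylphenyl, 2,4,6-trimethylphenyl or 2-chloro-4-methoxyphenyl would begin to separate these. Going by these compounds, it also remains open whether the same swap would give a step of similar size and direction with another amino group, such as the ethyl(propyl)amino group of compound 1 or the (cyclopropylmethyl)(propyl)amino group of compound 2.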